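Para-substituted anilides of a boron-containing core

This account rests on a few compounds, and the source may have more. Where it says the series, first, only, none or still open, it means among the compounds named here.

Measured compounds and their values:
compound 1 `O=C(CCc1cccc2c1B(O)OC2)Nc1ccccc1`: 350 nM
compound 2 `O=C(CCc1cccc2c1B(O)OC2)Nc1ccc(F)cc1`: 650 nM
compound 3 `COc1ccc(NC(=O)CCc2cccc3c2B(O)OC3)cc1`: 1700 nM

All three share the core of compound 1 and differ only in the group on the aromatic carbon para to the large group. In a functional assay on HCT-116 cells (Homo sapiens) for antiproliferative activity, read by MTT assay, with a stated time of 72 h (on this read-out lower numbers stand for stronger inhibition and higher numbers for weaker inhibition), compound 2 gives 650 nM and stands second highest of the three numbers: the step of a 1.9-fold higher number from compound 1 to compound 2 (0.27 log units; within the scatter) is within the scatter, whereas the step of a 2.6-fold higher number from compound 2 to compound 3 (0.42 log units; beyond the scatter) lies beyond it.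

Compound 4 `O=C(CCc1cccc2c1B(O)OC2)Nc1ccc([N+](=O)[O-])cc1` has not been measured. The change is nitro in place of fluoro on an aromatic carbon. The measured steps that bear on it are a 1.9-fold higher number from compound 1 to compound 2 (0.27 log units; within the scatter) and a 4.9-fold higher number from compound 1 to compound 3 (0.69 log units; beyond the scatter): each group entering at this place gives a higher number than hydrogen, and the two groups do not agree on size. Nitro is not among the measured groups, so the direction rests on both substituted compounds giving higher numbers than compound 1. A modest rise beyond the scatter is expected in this assay for compound 4, estimated as 1200 nM with range 500 nM to 3000 nM. The expected step of a 1.8-fold higher number from compound 2 to compound 4 (0.27 log units; within the scatter) is uncertain in size because a 2.6-fold higher number from compound 2 to compound 3 (0.42 log units; beyond the scatter) shows that a second replacement of fluoro at this place raised the number further.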

Compound 4, half-maximal inhibitory concentration: > 100000 nM
Compound 4: no number, only a limit; the forecaster's own chance of this, stated with the estimate: 3%; middle value at least 83-fold (1.92 log units) from the limit.
By their numbers in this assay, from the lowest: compounds 1 and 2 (each within the scatter of the next); then compound 3. At a limit, above all of these: compound 4.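

At this place, on an aromatic carbon para to a large group, compound 4 gives only a limit and not a number in this assay: the limit of > 100000 nM in this assay, at which 1 of the 4 values shown sits. Nitro brings steps of another order than those among compounds 1, 2 and 3: an at least 150-fold higher number from compound 2 to compound 4 (2.18 log units; beyond the scatter), an at least 58-fold higher number from compound 3 to compound 4 (1.76 log units; beyond the scatter) and an at least 280-fold higher number from compound 1 to compound 4 (2.45 log units; beyond the scatter), all of them large. Among these compounds, this place is therefore not one where replacing the group only shifts the number slightly, and the earlier steps, at most modest, gave no sign of a change of this size.

On these data alone, it stays open whether this large rise belongs to nitro alone or also appears with other groups here, such as an amine, a nitrile or a carboxylic acid. As far as these compounds go, with only a limit for compound 4, the full size of its steps also stays open.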